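The source may report more compounds than this note shows. Statements on the series, on what has been measured and on what is new or still open speak of the compounds shown alone.

Measured compounds:
- compound 1 `CC(C(=O)O)c1nn(Cc2cn3cc(OCC4CC4)c(Cl)cc3n2)c2ccccc2c1=O` gives 1.3 nM in a functional assay on HFL1 cells for antagonist activity at sphingosine 1-phosphate receptor 2 (Homo sapiens), read by ELISA, with a stated time of 24 h; a higher number here means a weaker inhibitor, a lower number a stronger inhibitor
- compound 2 `C[C@@H](C(=O)O)c1nn(Cc2cn3cc(OCC4CC4)c(Cl)cc3n2)c2ccccc2c1=O` gives 182 nM in this assay
- compound 3 `O=C(O)C1(c2nn(Cc3cn4cc(OCC5CC5)c(Cl)cc4n3)c3ccccc3c2=O)CC1` gives 28 nM in this assay

Compound 3 stands second highest of the three numbers; compound 2 is its nearest neighbour and compound 1 its furthest. For the measured compounds named here, the step of a 140-fold higher number from compound 1 to compound 2 (2.15 log units; beyond the scatter) is the largest in the set, and the fact that one of compounds 1 and 2 is drawn with a defined configuration and the other without, at the place where they differ is the one piece of evidence bearing on it. The two steps that replace 1-carboxyethyl with 1-carboxycyclopropyl run in opposite directions: a 22-fold higher number from compound 1 to compound 3 (1.33 log units; beyond the scatter) and a 6.5-fold lower number from compound 2 to compound 3 (0.81 log units; beyond the scatter).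

Compound 4 `CCC(C(=O)O)c1nn(Cc2cn3cc(OCC4CC4)c(Cl)cc3n2)c2ccccc2c1=O` is not yet measured. The change from compound 3 is 1-carboxypropyl in place of 1-carboxycyclopropyl on an aromatic carbon. Like compound 1, compound 4 is drawn without a configuration at the chain carbon. Going by the values given here, no measured pair shows the effect of lengthening the chain by one carbon, so the expectation rests on compound 1 and its step of a 22-fold higher number from compound 1 to compound 3 (1.33 log units; beyond the scatter), tempered by the fact that compound 2 sits on the other side of compound 3. On that basis the expected step is a 4.7-fold lower number from compound 3 to compound 4 (0.67 log units; beyond the scatter), a lower number than compound 3 in this assay. The estimate for compound 4 is 6 nM, with a range from 1 nM to 40 nM.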

Compound 4, half-maximal inhibitory concentration: 5.6 nM
Compound 4: the middle estimate sits 1.1-fold (0.03 log units) above what was measured; the range from low to high includes it.
By their numbers in this assay, from the lowest: compound 1; then compound 4; then compound 3; then compound 2.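

In this assay, 1-carboxypropyl in place of 1-carboxycyclopropyl, with the heavy-atom count unchanged and the three-membered ring gone, gives a 5.0-fold lower number from compound 3 to compound 4 (0.70 log units; beyond the scatter), so at this position the open chain gives the lower number of the pair. Methyl in place of hydrogen on the saturated chain carbon gives a 4.3-fold higher number from compound 1 to compound 4 (0.63 log units; beyond the scatter), the first reading of chain length here, between two compounds drawn without a configuration at that carbon, and the longer chain does not reach the lower number of the shorter one. The larger step, a 33-fold lower number from compound 2 to compound 4 (1.51 log units; beyond the scatter), also spans a defined configuration against an undefined one, so it cannot be read as chain length alone, and the only evidence on that difference is the one already bearing on the shorter-chain pair: the fact that one of compounds 1 and 2 is drawn with a defined configuration and the other without, at the place where they differ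

From the compounds shown here alone, how the two separate configurations of 1-carboxypropyl compare remains open, as does how far each contributes to the value of the undrawn form. Also open, going by these compounds, is how a longer chain such as 1-carboxybutyl, a larger ring such as 1-carboxycyclobutyl, or a primary amide in place of the carboxylic acid would read at this position.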